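A few compounds are considered here, and "the series" means these few. Any claim that something is new, unique, unknown or untested is made for them only; others in the source may bear on it.

Working notes on the series, read in a functional assay on HCT-116 cells (Homo sapiens), read by MTT assay, with a stated time of 72 h; on this read-out higher numbers stand for weaker inhibition and lower numbers for stronger inhibition. Compound 1 `CSc1ncnc2c1c(-c1ccsc1)cn2[C@@H]1O[C@H](CO)[C@@H](O)[C@H]1O` gives > 20000 nM, which is a limit and not a number. Compound 2 `CN(C)c1ncnc2c1c(-c1ccsc1)cn2[C@@H]1O[C@H](CO)[C@@H](O)[C@H]1O` gives > 20000 nM, also a limit. Compound 3 `CN(C)c1ncnc2c1c(-c1cc3ccccc3o1)cn2[C@@H]1O[C@H](CO)[C@@H](O)[C@H]1O` gives > 20000 nM, again a limit. Compound 2 therefore has no numerical position, and the whole set rests on (the limit of > 20000 nM in this assay, at which 3 of the 3 values shown sit).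

Compound 4 `Cc1ncnc2c1c(-c1ccsc1)cn2[C@@H]1O[C@H](CO)[C@@H](O)[C@H]1O` has methyl in place of dimethylamino on an aromatic carbon, relative to compound 2: methyl in place of dimethylamino on an aromatic carbon.

Among the compounds with values here, two measured steps bear on this change. The closer is a step that the two limits leave unreadable from compound 1 to compound 2, since it also exchanges the dimethylamino group. The other is a step that the two limits leave unreadable from compound 2 to compound 3, which concerns a different group. Neither gives a size, so the series supplies no measured basis for the step and only a tentative direction, towards stronger inhibition in this assay, is expected. The estimated step is an at least 2.5-fold lower number from compound 2 to compound 4 (0.39 log units; beyond the scatter). A further limit reading is as likely as a number.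

For compound 4 the expected value is 8000 nM, with an estimated range of 800 nM to 20000 nM.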

Compound 4, half-maximal inhibitory concentration: 1430 nM
Estimate against measurement, compound 4: 5.6-fold (0.75 log units) above, within the range that was stated.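

Compound 4 is the only compound shown that gives a number in this assay, so this position can now be read: methyl in place of dimethylamino gives an at least 13-fold lower number from compound 2 to compound 4 (1.14 log units; beyond the scatter), and methyl in place of methylsulfanyl gives an at least 13-fold lower number from compound 1 to compound 4 (1.14 log units; beyond the scatter). Both steps start from a limit, so each size is a minimum, and the two groups that leave cannot be ranked against each other. With thiophen-3-yl held constant, the change at this one position separates compound 4 from the rest of the set: the limit of > 20000 nM in this assay, at which 3 of the 4 values shown sit.

Going by these compounds, whether the lower number belongs to methyl itself or to the departure of the larger groups stays open, as does the reading of a hydrogen, an ethyl group or a primary amine at this position. Also open, on these data alone, is whether methyl would give a number alongside 1-benzofuran-2-yl.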